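Working notes on cytotoxicity within the chloroaryl series

The compounds below may be only part of what the source reports. "The series", "measured", "known", "first", "only" and "open" are said of these compounds alone.

Compound 3 `COc1cc(OC)nc(Nc2ccc(Cl)c(OCC=C(C)C)c2)n1` gives 28000 nM in an ADME assay on MT2 cells (Homo sapiens) for cytotoxicity (on this read-out lower numbers stand for higher toxicity in this test and higher numbers for lower toxicity in this test), the highest of the three numbers in hand. Compound 1 `COc1ccnc(Nc2ccc(Cl)c(OCC=C(C)C)c2)n1` gives 9000 nM and compound 2 `CC(C)=CCOc1cc(Nc2nccc(N)n2)ccc1Cl` gives 500 nM in this assay. The measured steps are a 3.1-fold higher number from compound 1 to compound 3 (0.49 log units; beyond the scatter) and an 18-fold lower number from compound 1 to compound 2 (1.26 log units; beyond the scatter). Compound 4 `COc1cc(N)nc(Nc2ccc(Cl)c(OCC=C(C)C)c2)n1` has not yet been measured; it differs from compound 3 by amino in place of methoxy on an aromatic carbon. Among the compounds with values here, the same change was seen as an 18-fold lower number from compound 1 to compound 2 (1.26 log units; beyond the scatter), a large step, so a large step downward is expected in this assay here as well, with only that one pair to support it. Compound 4 is therefore expected to give about 1600 nM, with a likely range from 500 nM to 5000 nM. The expected step of an 18-fold lower number from compound 3 to compound 4 (1.24 log units; beyond the scatter) mirrors the earlier one.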

Compound 4, half-maximal cytotoxic concentration: 19000 nM
Estimate against measurement, compound 4: 12-fold (1.07 log units) below; measured number above the stated range.
By their numbers in this assay, from the lowest: compound 2; then compound 1; then compounds 4 and 3 (each within the scatter of the next).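

In this assay, amino in place of methoxy on this aromatic carbon gives a 1.5-fold lower number from compound 3 to compound 4 (0.17 log units; within the scatter), so the size of this change depends on the core: the same change on two cores in this assay, an 18-fold lower number (1.26 log units; beyond the scatter) from compound 1 to compound 2 and a 1.5-fold lower number (0.17 log units; within the scatter) from compound 3 to compound 4, 12-fold (1.09 log units) apart, beyond the scatter of two such steps. The methoxy group retained in compound 4 also counts for more on the core of compound 2, with a 38-fold higher number from compound 2 to compound 4 (1.58 log units; beyond the scatter) as the step: the same change on two cores in this assay, a 3.1-fold higher number (0.49 log units; beyond the scatter) from compound 1 to compound 3 and a 38-fold higher number (1.58 log units; beyond the scatter) from compound 2 to compound 4, 12-fold (1.09 log units) apart, beyond the scatter of two such steps. Amino in place of hydrogen gives a 2.1-fold higher number from compound 1 to compound 4 (0.32 log units; beyond the scatter) as its step.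

Going by these compounds, what a dimethylamino group or an ethoxy group would give at this position stays open. So does whether this dependence on the core extends beyond these four compounds.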